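The source may hold more compounds than are shown below. What is called first, only, known or untested is meant among the compounds shown, and "the series" means these compounds.

Compound 1 `C[C@H](NC(=O)CC(F)(F)F)c1ccc(NC(=O)[C@H]2C[C@@H]2c2cccnc2)cc1`, compound 2 `C[C@H](NC(=O)C1CCOCC1)c1ccc(NC(=O)[C@H]2C[C@@H]2c2cccnc2)cc1` and compound 3 `C[C@H](NC(=O)c1ccc(C#N)cc1)c1ccc(NC(=O)[C@H]2C[C@@H]2c2cccnc2)cc1` share one core and differ only in the group joined to a carbonyl carbon. In an ADME assay on microsomes from liver (Mus musculus) for pharmacokinetics (a higher number here means faster removal of the compound, a lower number slower removal), compound 1 gives 83.7 mL.min-1.g-1, compound 2 gives 25.1 mL.min-1.g-1 and compound 3 gives 53 mL.min-1.g-1. Compound 1 therefore shows the highest number of the three, with compound 3 nearest to it and compound 2 furthest away. Compound 4 `C[C@H](NC(=O)c1ccccn1)c1ccc(NC(=O)[C@H]2C[C@@H]2c2cccnc2)cc1` has not yet been measured. It differs from compound 1 in one place: pyridin-2-yl in place of 2,2,2-trifluoroethyl on a carbonyl carbon. Among the measured compounds shown here, two measured steps bear on this change, since each also replaces the 2,2,2-trifluoroethyl group on the same carbonyl carbon with a ring: a 3.3-fold lower number from compound 1 to compound 2 (0.52 log units; beyond the scatter), and a 1.6-fold lower number from compound 1 to compound 3 (0.20 log units; within the scatter). Both point to a lower number, the move to a six-membered aromatic ring being the smaller of the two. A number lower than that of compound 1 is expected for compound 4, which brings in a six-membered aromatic ring with one hetero atom. The expected step is a 2.1-fold lower number from compound 1 to compound 4 (0.32 log units; beyond the scatter), between the two measured steps. The estimate for compound 4 in this assay is 40 mL.min-1.g-1, with a likely range from 18 mL.min-1.g-1 to 90 mL.min-1.g-1.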

Compound 4, intrinsic clearance in microsomes: < 3.42 mL.min-1.g-1
Compound 4 gave a limit, no number; the forecaster's own chance of this, stated with the estimate: 0%; middle value at least 11-fold (1.06 log units) away from the limit.
By their numbers in this assay, from the lowest: compound 2; then compounds 3 and 1 (each within the scatter of the next). At a limit, below all of these: compound 4.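

In this assay, compound 4 gave a limit and not a number: the limit of < 3.42 mL.min-1.g-1 in this assay, at which 1 of the 4 values shown sits. Among compounds 1, 2 and 3, changing the group on this carbonyl carbon gave steps no larger than modest, but the pyridin-2-yl group shows that this position can produce a much larger change, with an at least 24-fold lower number from compound 1 to compound 4 (1.38 log units; beyond the scatter), an at least 15-fold lower number from compound 3 to compound 4 (1.19 log units; beyond the scatter) and an at least 7.3-fold lower number from compound 2 to compound 4 (0.86 log units; beyond the scatter). Compounds 2 and 3 also carry a ring at this position and still give measurable numbers, so the presence of a ring alone does not account for the drop, and the step from compound 3 shows that a six-membered aromatic ring alone does not either.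

The compounds shown leave open whether the ring nitrogen of the pyridin-2-yl group is what matters, a question that a plain phenyl, pyridin-3-yl or pyridin-4-yl group on the same carbonyl carbon could help to settle. On these data alone, how far the true value of compound 4 lies beyond its limit also remains unknown, so the full size of each of its steps stays open.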